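This account rests on a few compounds, and the source may have more. Where it says the series, first, only, none or still open, it means among the compounds named here.

For the measured compounds named here, compound 1 `CC#CC(CC(=O)O)c1ccc(OCc2ccn3cc(-c4ccc(C(C)C)cc4)nc3c2)cc1` is one of three compounds measured in an assay on isolated protein for agonist activity at Free fatty acid receptor 1 (Homo sapiens) (on this read-out higher numbers stand for an effect only at larger amounts of compound and lower numbers for an effect already at smaller amounts), where compound 1 gives 615 nM. Compound 2 `CC#CC(CC(=O)O)c1ccc(OCc2ccc3nc(-c4ccc(C(C)C)cc4)cn3c2)cc1` gives 528 nM, and compound 3 `CC#CC(CC(=O)O)c1ccc(OCc2ccc3nc(-c4ccc(C5CCCCC5)cc4)cn3c2)cc1` gives 417 nM. Compound 1 has the highest of the three numbers, yet its nearest neighbour, compound 2, and its furthest, compound 3, both lie within the usual scatter of it, so the three cannot be told apart. Going by the values given here, the only single-point step among them, a 1.3-fold lower number from compound 2 to compound 3 (0.10 log units; within the scatter), also stays within the scatter.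

Compound 4 `CC#CC(CC(=O)O)c1ccc(OCc2ccn3cc(-c4ccccc4F)nc3c2)cc1` has not yet been measured. It differs from compound 1 in one place: 2-fluorophenyl in place of 4-isopropylphenyl on an aromatic carbon. No measured step bears directly on this change; the one step shown swaps cyclohexyl for isopropyl and keeps a substituted phenyl, whereas here the 4-isopropylphenyl leaves entirely and a 2-fluorophenyl enters. Among the compounds with values here, with no guiding step, the size is uncertain, and the step from compound 1 to compound 4 is estimated as a 1.8-fold higher number from compound 1 to compound 4 (0.25 log units; within the scatter). Compound 4 is therefore expected to give about 1100 nM, with a range from 350 nM to 3500 nM.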

Compound 4, half-maximal effective concentration: 705 nM
The estimate for compound 4 lay 1.6-fold (0.19 log units) above the measured number; measured number inside the range.
By their numbers in this assay, from the lowest: compounds 3, 2, 1 and 4 (each within the scatter of the next).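

Swapping the 4-isopropylphenyl for a 2-fluorophenyl, on an aromatic carbon of the five-membered ring with 2 nitrogen, amounts in this assay to a 1.1-fold higher number from compound 1 to compound 4 (0.06 log units; within the scatter). This position therefore accepts a quite different substituted phenyl without a readable shift in the number, whereas the earlier step only exchanged isopropyl for cyclohexyl on a phenyl in compounds with a different core. Nothing available explains this outcome.

As far as these compounds go, two things changed at once, the isopropyl group leaving and a fluorine entering, so the contribution of each remains unknown, and an unsubstituted phenyl at this place would help to separate them. From the compounds shown here alone, it also remains open whether a phenyl is needed here at all, which a non-aromatic group such as morpholine or a simple methyl could test.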